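Compound 4: a Smaller Side Group, Low Cytotoxicity Expected

The compounds below may be only part of what the source reports. "The series", "measured", "known", "first", "only" and "open" are said of these compounds alone.

Compound 3 `O=C1CSC(=O)N1C[C@H]1CN(c2ccc(-n3cc(-c4ccccn4)cn3)c(F)c2)C(=O)O1` was tested in an ADME assay on L02 cells (Homo sapiens) for cytotoxicity, read by MTT assay, with a stated time of 48 h; a higher number here means a weaker inhibitor, a lower number a stronger inhibitor. In this assay compound 3 gives only a limit, > 400 ug/mL. Compound 2 `O=C1O[C@@H](CN2CCCCC2)CN1c1ccc(-n2cc(-c3ccccn3)cn2)c(F)c1` also gives only a limit, > 400 ug/mL. For the measured compounds named here, the single numerical value comes from compound 1 `O=C1O[C@@H](CO)CN1c1ccc(-n2cc(-c3ccccn3)cn2)c(F)c1`, which in this assay gives 59 ug/mL. The two readable steps, an at least 6.7-fold higher number from compound 1 to compound 2 (0.83 log units; beyond the scatter) and an at least 6.7-fold higher number from compound 1 to compound 3 (0.83 log units; beyond the scatter), both replace the hydroxy of compound 1 with a larger group and both end at the limit (the limit of > 400 ug/mL in this assay, at which 2 of the 3 values shown sit). Between them, the step that the two limits leave unreadable from compound 2 to compound 3.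

Compound 4 `O=CNC[C@H]1CN(c2ccc(-n3cc(-c4ccccn4)cn3)c(F)c2)C(=O)O1` differs from compound 3 by formylamino in place of 2,4-dioxo-1,3-thiazolidin-3-yl on a saturated chain carbon bound to a saturated ring carbon. Going by the values given here, no measured step covers this exact change; the readable steps show only that replacing hydroxy with a larger group raised the number. Formylamino is smaller than either replacement and brings back a hydrogen-bond donor, as hydroxy in compound 1 has, so compound 4 is expected to sit between compound 1 and the limit, with an estimated value of 200 ug/mL (range 60 ug/mL to 400 ug/mL). That estimate means an expected step of an at least 2.0-fold lower number from compound 3 to compound 4 (0.30 log units; that floor lies within the scatter), with a fair chance the assay again reports only a limit.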

Compound 4, half-maximal inhibitory concentration: > 400 ug/mL
Compound 4: a limit, no number; the forecaster's own chance of this, stated with the estimate: 45%; middle value at least 2.0-fold (0.30 log units) from the limit.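

Compound 4 gives only a limit in this assay, not a number. Formylamino in place of hydroxy still gives an at least 6.7-fold higher number from compound 1 to compound 4 (0.83 log units; beyond the scatter), so on this saturated chain carbon, the number can rise with a replacing group that has no ring and keeps a hydrogen-bond donor, unlike the replacing groups in compound 2 and compound 3. The steps among compound 2, compound 3 and compound 4 cannot be read, and these compounds cannot be ranked against one another: the limit of > 400 ug/mL in this assay, at which 3 of the 4 values shown sit.

On these data alone, how far the true values of these three compounds lie past the limit stays open. Also open, as far as these compounds go, is whether a primary amine or a methoxy group at this place would give a measurable number, as the hydroxy of compound 1 does.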